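A Shorter Side Chain and Cell Tolerance

A few compounds are considered here, and "the series" means these few. Any claim that something is new, unique, unknown or untested is made for them only; others in the source may bear on it.

Compound 1, `CCCCc1csc(CN[C@@H]2C[C@H]3C[C@@H]([C@H]2C)C3(C)C)c1`, was tested in an ADME assay on MDCK cells (Canis lupus familiaris) for cytotoxicity, read by microscopy, with a stated time of 48 h (a lower number here means that less compound is tolerated, a higher number that more compound is tolerated), and gave 12500 nM. This is the lowest of the three numbers at hand, so compound 1 is the least tolerated. Compound 3, `C[C@H]1[C@H](NCc2ccc(Br)s2)C[C@H]2C[C@@H]1C2(C)C`, gives 43000 nM, and compound 2, `CCCc1ccsc1CN[C@@H]1C[C@H]2C[C@@H]([C@H]1C)C2(C)C`, gives 50000 nM; both gaps from compound 1 lie beyond the usual scatter. Compound 4, `C=C(C)c1csc(CN[C@@H]2C[C@H]3C[C@@H]([C@H]2C)C3(C)C)c1`, has not yet been measured. It differs from compound 1 in one place: 1-methylethenyl in place of butyl on an aromatic carbon. Because compound 3 gives 43000 nM and compound 2 gives 50000 nM, a modest rise in tolerated concentration is expected for compound 4, though the step may stay within the scatter. For compound 4 the estimate in this assay is 25000 nM, with a range from 10000 nM to 60000 nM. This estimate means the expected step of a 2.0-fold higher number from compound 1 to compound 4 (0.30 log units; within the scatter).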

Compound 4, minimum cytotoxic concentration: 25000 nM
Compound 4: the middle estimate sits on the measured number at the digits printed; the range from low to high includes it.
By their numbers in this assay, from the lowest: compounds 1, 4, 3 and 2 (each within the scatter of the next, the first and the last beyond it).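

Among these compounds, this pair is the first in the set to differ in one place, so this position can now be read directly: in this assay, 1-methylethenyl in place of butyl gives a 2.0-fold higher number from compound 1 to compound 4 (0.30 log units; within the scatter) and stays within the scatter. At this ring carbon, two ring bonds from the ring sulfur, the two groups cannot be told apart by tolerated concentration, even though only one carries a double bond. No measured evidence on the cause of this step is at hand.

From the compounds shown here alone, what 1-methylethyl, the same branched group without the double bond, would give here remains open. So does the outcome for an amine or a longer chain at this position.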